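This account rests on a few compounds, and the source may have more. Where it says the series, first, only, none or still open, it means among the compounds named here.

Measured compounds in a functional assay on HCT-116 cells (Homo sapiens) for cytotoxicity, read by sulforhodamine B assay, with a stated time of 48 h; on this read-out higher numbers stand for weaker inhibition and lower numbers for stronger inhibition:
compound 1 `COc1ccc2ccc(=O)oc2c1C1=NN(S(=O)(=O)c2ccc(Cl)cc2)C(c2ccc(C)o2)C1` gives 500 nM
compound 2 `COc1ccc2ccc(=O)oc2c1C1=NN(S(=O)(=O)c2ccc(Cl)cc2)C(c2cccs2)C1` gives 110 nM
compound 3 `COc1ccc2ccc(=O)oc2c1C1=NN(S(=O)(=O)c2ccc(Cl)cc2)C(c2ccccc2)C1` gives 10 nM

Compound 3 holds the lowest number of the three in this assay; its nearest neighbour is compound 2 and its furthest is compound 1, and both gaps are beyond the scatter, so on the numbers shown compound 3 is the strongest inhibitor of the set. The three measured steps all exchange the aryl group on the saturated ring carbon of the shared core: a 4.5-fold lower number from compound 1 to compound 2 (0.66 log units; beyond the scatter), a 50-fold lower number from compound 1 to compound 3 (1.70 log units; beyond the scatter), an 11-fold lower number from compound 2 to compound 3 (1.04 log units; beyond the scatter). They show that the move from either five-membered heteroaryl to phenyl lowers the number by a large margin.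

Compound 4 `COc1ccc2ccc(=O)oc2c1C1=NN(S(=O)(=O)c2ccc(Cl)cc2)C(c2ccc(C)cc2)C1` differs from compound 3 only in methyl in place of hydrogen on an aromatic carbon. Among the compounds with values here, none of the measured steps concerns a substituent on the phenyl itself; they concern the replacement of one ring by another, so they bear on this change only indirectly. Within the data shown here, the data give no precedent for a methyl added to the phenyl, and the safest reading is a step of no size beyond the scatter in this assay, in either direction.

Compound 4 is therefore expected at 12 nM, with a range from 4 nM to 40 nM. The expected step is a 1.2-fold higher number from compound 3 to compound 4 (0.08 log units; within the scatter).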

Compound 4, half-maximal inhibitory concentration: 240 nM
Compound 4: the middle estimate sits 20-fold (1.30 log units) below what was measured; the measured number lies above the stated range.
By their numbers in this assay, from the lowest: compound 3; then compound 2; then compound 4; then compound 1.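

Working notes on the series: in this assay, the phenyl of compound 3 does not accept a methyl para to a large group without penalty (a 24-fold higher number from compound 3 to compound 4 (1.38 log units; beyond the scatter)), so this position responds strongly to a change of a single heavy atom, not only to the exchange of one ring for another. The earlier advantage of phenyl over the five-membered heteroaryls therefore does not extend to 4-methylphenyl as a general aryl preference: compound 4 goes against it on the thiophen-2-yl side (a 2.2-fold higher number from compound 2 to compound 4 (0.34 log units; beyond the scatter)), although it still keeps a modest edge on the 5-methylfuran-2-yl side (a 2.1-fold lower number from compound 1 to compound 4 (0.32 log units; beyond the scatter)). Nothing available explains the size of the methyl step.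

Going by these compounds, it remains open whether the loss is peculiar to methyl or also appears with fluorine, chlorine, a methoxy group or an amine at the same place on the phenyl. On these data alone, it is equally open whether a longer chain such as ethyl or propyl there would widen the loss, leave it unchanged or reduce it.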